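Amide-to-sulfonamide swap on the chain of compound 2

This account rests on a few compounds, and the source may have more. Where it says the series, first, only, none or still open, it means among the compounds named here.

For the measured compounds named here, the three measured members share one core and differ in the tail on the chain that hangs from the ring nitrogen. Compound 1 `Cc1ccc(S(=O)(=O)NCCCNc2nccc(-c3c(-c4cccc(F)c4)nc4sccn34)n2)cc1` gives 8380 nM in a functional assay on A-375 cells (Homo sapiens) for cytotoxicity, read by MTT assay; a higher number here means a weaker inhibitor, a lower number a stronger inhibitor. Compound 2 `O=C(NCCNc1nccc(-c2c(-c3cccc(F)c3)nc3sccn23)n1)c1ccccc1` gives 5060 nM in this assay, and compound 3 `COc1ccc(S(=O)(=O)NCCCNc2nccc(-c3c(-c4cccc(F)c4)nc4sccn34)n2)cc1` gives 5510 nM. Compound 2 has the lowest of the three numbers, but its nearest neighbour compound 3 sits only a 1.5-fold lower number from compound 1 to compound 3 (0.18 log units; within the scatter) away from compound 1, and the step of a 1.7-fold lower number from compound 1 to compound 2 (0.22 log units; within the scatter) is itself within the scatter, so nothing here separates the three beyond the scatter.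

Compound 4 `O=S(=O)(NCCNc1nccc(-c2c(-c3cccc(F)c3)nc3sccn23)n1)c1ccccc1` differs from compound 2 as follows: phenylsulfonyl in place of benzoyl on an amine nitrogen. Going by the values given here, the only measured step that touches this part of the molecule is a 1.7-fold lower number from compound 1 to compound 2 (0.22 log units; within the scatter), and it swaps the chain as well as the tail group; the other step, a 1.5-fold lower number from compound 1 to compound 3 (0.18 log units; within the scatter), concerns a methoxy for a methyl on an aromatic carbon and says nothing about the tail. Neither step left the scatter, so no step beyond the scatter is expected in this assay for this change either. Compound 4 is therefore estimated at 6000 nM, within 2500 nM to 15000 nM, which would be a step of a 1.2-fold higher number from compound 2 to compound 4 (0.07 log units; within the scatter).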

Compound 4, half-maximal inhibitory concentration: 11000 nM
Beside the measured number, compound 4's estimate is 1.8-fold (0.26 log units) below it; the measured number falls inside the stated range.
By their numbers in this assay, from the lowest: compounds 2, 3, 1 and 4 (each within the scatter of the next, the first and the last beyond it).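

Phenylsulfonyl in place of benzoyl on the amine nitrogen gives a 2.2-fold higher number from compound 2 to compound 4 (0.34 log units; beyond the scatter) in this assay and this modest step is the first in the series to leave the scatter. The group on this nitrogen therefore registers in the read-out, although the other new step of a 1.3-fold higher number from compound 1 to compound 4 (0.12 log units; within the scatter) stays within the scatter and leaves the two sulfonamide tails unseparated. No measured information on these compounds accounts for the step.

Going by these compounds, a single pair carries the comparison of phenylsulfonyl with benzoyl, so it remains open whether the same step would appear on a longer chain. Also open, on these data alone, is how this position responds to a smaller group such as methylsulfonyl, or to a phenyl ring carrying an amine or a carboxylic acid.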